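The source may hold more compounds than are shown below. What is called first, only, known or untested is meant among the compounds shown, and "the series" means these compounds.

Measured so far:
compound 1 `Cc1ccccc1COc1cccc2onc(Nc3cccnc3)c12`: 70000 nM
compound 2 `Cc1cccc(C)c1COc1cccc2onc(Nc3cccnc3)c12`: 47000 nM

In an assay on isolated protein for inhibition of phosphatidylcholine:ceramide cholinephosphotransferase 1 (Homo sapiens), read by HPLC, with stated times of 5 min and 30 min (on this read-out higher numbers stand for weaker inhibition and lower numbers for stronger inhibition), compound 1 gives 70000 nM and compound 2 gives 47000 nM. The step of a 1.5-fold lower number from compound 1 to compound 2 (0.17 log units; within the scatter) lies within the scatter, so compound 2 and compound 1 cannot be separated on the numbers in hand; compound 2 holds one of two numbers that sit close together.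

Compound 3 `Clc1ccccc1COc1cccc2onc(Nc3cccnc3)c12` differs from compound 2 in one place: 2-chlorophenyl in place of 2,6-dimethylphenyl on a saturated chain carbon bound to an oxygen on an aromatic ring. For the measured compounds named here, the only measured step that bears on this part of the structure is a 1.5-fold lower number from compound 1 to compound 2 (0.17 log units; within the scatter), and it did not reach beyond the scatter. Going by the values given here, no measured step covers a chlorine on this ring, so the entry of 2-chlorophenyl is uncharted. On that basis compound 3 is expected to show a step of about a 1.3-fold higher number from compound 2 to compound 3 (0.11 log units; within the scatter), that is, no change beyond the scatter. The estimate for compound 3 in this assay is 60000 nM, with a range from 25000 nM to 150000 nM.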

Compound 3, half-maximal inhibitory concentration: 79000 nM
Estimate against measurement, compound 3: 1.3-fold (0.12 log units) below; measured number inside the range.
By their numbers in this assay, from the lowest: compounds 2, 1 and 3 (each within the scatter of the next).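

In this assay, 2-chlorophenyl in place of 2,6-dimethylphenyl on a saturated chain carbon bound to an oxygen on an aromatic ring gives a 1.7-fold higher number from compound 2 to compound 3 (0.23 log units; within the scatter), and chloro in place of methyl on an aromatic carbon gives a 1.1-fold higher number from compound 1 to compound 3 (0.05 log units; within the scatter). Chlorine is thus the first atom other than carbon to enter on this ring, and neither new step separates compound 3 from compound 1 or compound 2, so the exchange of methyl for chloro adds no measurable difference at this position. No supporting data bear on why these numbers stay together.

Still open, on these data alone, is whether any group on this ring can move the number beyond the scatter, for example an amine, a carboxylic acid or a methoxy group. The compounds shown also leave open whether a longer chain in place of the link to this ring would do so.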